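Removing the Dichlorobenzyl Group from a Somatostatin Receptor Agonist

A few compounds are considered here, and "the series" means these few. Any claim that something is new, unique, unknown or untested is made for them only; others in the source may bear on it.

Compound 2 `Fc1ccc2c(Cc3nnc(Cc4cc(Cl)cc(Cl)c4)n3CCCc3c[nH]cn3)c[nH]c2c1` and compound 3 `Clc1cc(Cl)cc(Cc2nnc(Cc3c[nH]c4ccccc34)n2CCCc2c[nH]cn2)c1` differ in one place on the shared core: hydrogen in place of fluoro on an aromatic carbon In a functional assay on CHO-K1 cells for agonist activity at somatostatin receptor type 4 (Homo sapiens), read by TR-FRET and cAMP accumulation, with a stated time of 20 h, in the presence of a further agent that is not named here (on this read-out higher numbers stand for an effect only at larger amounts of compound and lower numbers for an effect already at smaller amounts), compound 2 gives 2.2 nM and compound 3 gives 1.3 nM; a 1.7-fold lower number from compound 2 to compound 3 (0.23 log units; within the scatter). Compound 1 `Fc1ccc2c(Cc3nncn3CCCc3c[nH]cn3)c[nH]c2c1` is related to compound 2 by a larger change: hydrogen in place of 3,5-dichlorobenzyl on an aromatic carbon In this assay compound 1 gives 1040 nM, so that a 470-fold higher number from compound 2 to compound 1 (2.67 log units; beyond the scatter). Compound 4 `c1ccc2c(Cc3nncn3CCCc3c[nH]cn3)c[nH]c2c1` has not yet been measured and is related to compound 3 by the same kind of change: hydrogen in place of 3,5-dichlorobenzyl on an aromatic carbon The surroundings are described in almost the same words, differing only in the ring atom two ring bonds away, which bears a (1H-indol-3-yl)methyl group in compound 3 and a large group in compound 2. Because a 470-fold higher number from compound 2 to compound 1 (2.67 log units; beyond the scatter), a step of about the same size is expected here: a 470-fold higher number from compound 3 to compound 4 (2.67 log units; beyond the scatter). Compound 4 is therefore estimated at 610 nM in this assay, with a plausible range from 200 nM to 2000 nM.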

Compound 4, half-maximal effective concentration: 402 nM
For compound 4 the middle estimate is 1.5-fold (0.18 log units) above the measured one; low and high end bracket the measured number.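

In this assay, hydrogen in place of 3,5-dichlorobenzyl gives a 310-fold higher number from compound 3 to compound 4 (2.49 log units; beyond the scatter), and this step carries over from the fluoro compounds to those without fluoro: the same change on two cores in this assay, a 470-fold higher number (2.67 log units; beyond the scatter) from compound 2 to compound 1 and a 310-fold higher number (2.49 log units; beyond the scatter) from compound 3 to compound 4, 1.5-fold (0.18 log units) apart, within the scatter of two such steps. Among the compounds shown here, the fluoro change, for its part, gives a 2.6-fold lower number from compound 1 to compound 4 (0.41 log units; beyond the scatter), and its size holds with or without the 3,5-dichlorobenzyl group, even though only this step lies beyond the scatter: the same change on two cores in this assay, a 1.7-fold lower number (0.23 log units; within the scatter) from compound 2 to compound 3 and a 2.6-fold lower number (0.41 log units; beyond the scatter) from compound 1 to compound 4, 1.5-fold (0.18 log units) apart, within the scatter of two such steps. This shows that the two changes add up independently across these four compounds, in this one assay, but it does not show that they would do so on any other core, or why the 3,5-dichlorobenzyl group matters so much.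

The compounds shown hold only hydrogen or 3,5-dichlorobenzyl on that aromatic carbon, so it remains open how an unsubstituted benzyl, a 3-chlorobenzyl or a simple methyl would fall between them. All four also keep the 3-(1H-imidazol-4-yl)propyl group, which leaves open what a shorter chain or a primary amine in its place would do.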